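The source may hold more compounds than are shown below. What is called first, only, known or untested is meant among the compounds shown, and "the series" means these compounds.

Going by the values given here, compound 2 `CCCCCCNc1ncnc2c1nnn2[C@@H]1C[C@@H](COS(N)(=O)=O)[C@@H](O)C1` is the one compound here with a numerical result: in an assay on a protein complex for inhibition of NEDD8 activating enzyme (Homo sapiens), read by HTRF, with a stated time of 2 h, in the presence of a further agent that is not named here (a higher number here means a weaker inhibitor, a lower number a stronger inhibitor), compound 2 gives 21.1 nM. Compound 1 `NS(=O)(=O)OC[C@@H]1C[C@@H](n2ncc3c(N[C@H]4CCc5ccccc54)ccnc32)C[C@@H]1O` returns only a limit of this assay, namely > 10000 nM. That picture is summed up by the limit of > 10000 nM in this assay, at which 1 of the 2 values shown sits. Compound 3 `NS(=O)(=O)OC[C@@H]1C[C@@H](n2nnc3c(Nn4ccc5ccccc54)ncnc32)C[C@@H]1O` differs from compound 2 in a single place: 1H-indol-1-yl in place of hexyl on a nitrogen on an aromatic ring. Among the compounds with values here, no measured pair covers a change of this kind, so the expectation rests on compound 2 alone and carries real uncertainty. The change is expected to weaken inhibition beyond the usual scatter, with a step of a 14-fold higher number from compound 2 to compound 3 (1.15 log units; beyond the scatter). Compound 3 is therefore estimated to give in this assay about 300 nM, within a range from 40 nM to 3000 nM.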

Compound 3, half-maximal inhibitory concentration: > 10000 nM
Compound 3 ended at the assay's limit; the forecaster's own chance of this, stated with the estimate: 20%; at least 33-fold (1.52 log units) between middle value and limit.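

The pair shows that inhibition in this assay depends strongly on the group at this position, which a single compound carrying hexyl could not reveal. With the rest of the structure unchanged, replacing hexyl with 1H-indol-1-yl gives an at least 470-fold higher number from compound 2 to compound 3 (2.67 log units; beyond the scatter), so this nitrogen on an aromatic ring does not accept every group. Compound 3 gives only a limit of this assay, and such a result is common in this small set: the limit of > 10000 nM in this assay, at which 2 of the 3 values shown sit.

With only hexyl and 1H-indol-1-yl to compare in this single-change pair, the compounds shown cannot separate the effect of losing the chain from that of adding the two rings. They also leave open whether a shorter chain such as butyl, or a benzyl group, would keep inhibition close to that of compound 2.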